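Swapping an Amino Group for a Hydroxy Group

A few compounds are considered here, and "the series" means these few. Any claim that something is new, unique, unknown or untested is made for them only; others in the source may bear on it.

Of the compounds shown here, three have been measured in a physicochemical assay for lipophilicity, read by HPLC, at pH 7.4; a higher number here means a more lipophilic compound, a lower number a more polar compound. Compound 1 `COc1ccc(-c2cc(-c3ccc(S(C)(=O)=O)cc3)cnc2C(F)(F)F)cn1` gives 3. Compound 2 `COc1ccc(-c2cc(-c3ccc(S(C)(=O)=O)cc3)cnc2N)cn1` gives 2.2, and compound 3 `COc1ccc(-c2nc(-c3ccc(S(C)(=O)=O)cc3)cnc2N)cn1` gives 2.3. Compound 2 has the lowest of the three numbers, though compound 3 sits within the scatter of it, and only compound 1 stands beyond the scatter, higher. Within the data shown here, the single step that can be read between two measured compounds differing in one place is a number 0.80 log units lower from compound 1 to compound 2 (beyond the scatter), amino in place of trifluoromethyl on an aromatic carbon.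

Compound 4 `COc1ccc(-c2cc(-c3ccc(S(C)(=O)=O)cc3)cnc2O)cn1` has not yet been measured. It differs from compound 2 in one place: hydroxy in place of amino on an aromatic carbon. Among the measured compounds shown here, no measured step in this assay exchanges amino for hydroxy, so the one step that has been measured does not bear directly on this change; it only shows that a change at this aromatic carbon can move the number by a modest amount. Both groups carry one hydrogen-bond donor and one hydrogen-bond acceptor, so a small downward step, a number 0.30 log units lower from compound 2 to compound 4 (within the scatter), is expected, close to the scatter. Compound 4 is therefore estimated at 1.9, within a range from 1.4 to 2.4.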

Compound 4, distribution coefficient: 1.7
Compound 4: the middle estimate sits 0.20 log units above what was measured; low and high end bracket the measured number.
By their numbers in this assay, from the lowest: compound 4; then compounds 2 and 3 (each within the scatter of the next); then compound 1.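

At this aromatic carbon next to the ring nitrogen, hydroxy in place of amino gives in this assay a number 0.50 log units lower from compound 2 to compound 4 (beyond the scatter) even though the two groups have the same counts of heavy atoms, hydrogen-bond donors and hydrogen-bond acceptors, so those matching counts do not keep the number in place. Measured against trifluoromethyl, hydroxy gives a number 1.30 log units lower from compound 1 to compound 4 (beyond the scatter) and so spans a wider range at this position than the earlier step with amino, a number 0.80 log units lower from compound 1 to compound 2 (beyond the scatter) and the three groups now stand apart, with trifluoromethyl highest, amino in the middle and hydroxy lowest. No measurement shown gives a reason for the difference between amino and hydroxy.

Where a methyl group, a nitrile or a carboxylic acid would fall at this same carbon among these three groups remains open. Among these compounds, it is also open whether hydroxy in place of amino would give a similar step on the core of compound 3, where the ring carrying the amino group differs from the one in compound 2.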